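Replacing dimethylcarbamoyl with cyano on a shared core

The compounds below may be only part of what the source reports. "The series", "measured", "known", "first", "only" and "open" are said of these compounds alone.

In a physicochemical assay for acid dissociation, read by spectrophotometry, at 25 degrees C, compound 1 (`CNC(=O)[C@]12C[C@H]1[C@@](C)(c1cc(NC(=O)c3ccc(Cl)cn3)cc(F)c1F)N=C(N)S2`) gives 6.7. Compound 2 (`CN(C)C(=O)[C@]12C[C@H]1[C@@](C)(c1cc(NC(=O)c3ccc(Cl)cn3)cc(F)c1F)N=C(N)S2`) gives 6.9, which places it within the scatter of compound 1, so the two numbers cannot be ranked. Compound 3 (`C[C@]1(c2cc(NC(=O)c3ccc(Cl)cn3)cc(F)c2F)N=C(N)S[C@@]2(C#N)C[C@H]21`) has not yet been measured. Its difference from compound 2 is cyano in place of dimethylcarbamoyl on a saturated ring carbon of a three-membered non-aromatic ring.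

Among the compounds with values here, only one measured step bears on this change, methyl in place of hydrogen on an amide-type nitrogen, and it amounts to a number 0.20 log units higher from compound 1 to compound 2 (within the scatter). That step edits the dimethylcarbamoyl group without removing it, so it sets no size for the swap to cyano. Within the data shown here, no measured pair here makes a swap of this kind, which means the expectation below is a judgement and carries a wide range. The expected step is a number 1.00 log units lower from compound 2 to compound 3 (beyond the scatter), which would mean a proton given up more readily and a change beyond the scatter. The estimated value for compound 3 is 5.9, with an expected range from 5.3 to 6.5.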

Compound 3, acid dissociation constant: 6.2
Compound 3: the middle estimate sits 0.30 log units below what was measured; low and high end bracket the measured number.
By their numbers in this assay, from the lowest: compound 3; then compounds 1 and 2 (each within the scatter of the next).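

In this assay the earlier pair showed only that adding a methyl to the amide nitrogen on this saturated ring carbon gave no change that could be ranked. Replacing the whole carbamoyl group is different: the swap to cyano gives a number 0.70 log units lower from compound 2 to compound 3 (beyond the scatter) and, starting from the methylcarbamoyl group, a number 0.50 log units lower from compound 1 to compound 3 (beyond the scatter) on the same shared core. So both steps show that this three-membered ring position can carry a change that this assay can distinguish from scatter, whichever of the two amides is the starting point, although no measurement available here explains why the number moves.

Cyano is the only non-amide group shown at this position, so a single replacement cannot show how far the number could move or in which directions. A trifluoromethyl group, a methyl ester, a plain hydrogen or a longer chain on this ring carbon would each test whether the step seen with cyano is particular to that group or is shared by other replacements for the amide in this assay on this core.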